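The source may hold more compounds than are shown below. What is called first, only, known or untested is meant among the compounds shown, and "the series" means these compounds.

Compound 1 `c1ccc(CCc2ccccc2CSc2ncc[nH]2)cc1` was tested in an assay on isolated protein for inhibition of Indoleamine 2,3-dioxygenase 1 (Homo sapiens), with a stated time of 60 min, tested at 10 uM (a lower number here means less inhibition, a higher number more inhibition at the concentration tested (going by the name of the read-out)), where compound 1 gives 19%. Two other compounds show where that number stands. Compound 3 `Clc1ccc2[nH]c(SCc3ccccc3CCCc3ccccc3)nc2c1` gives 19% in this assay, the same number at the digits shown, so the two cannot be told apart within the usual scatter of the method, and together they stand at the top of the three numbers. Compound 2 `c1ccc(CSc2nc3ccccc3[nH]2)cc1` gives -42% in this assay, a number far below that of compound 1, by a gap well beyond the scatter. No two of these three compounds differ in only one place, so none of them shows directly what a single change does.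

Compound 4 `c1ccc(CCc2ccccc2CSc2nccs2)cc1` has not yet been measured. It differs from compound 1 in one place: 1,3-thiazol-2-yl in place of 1H-imidazol-2-yl on a sulfur. Among the measured compounds shown here, none of the measured compounds carries this exact exchange, so the expectation rests on the size of the numbers so far, which are all modest. The step of a number 7 percentage points lower from compound 1 to compound 4 (within the scatter) is expected to be small, if anything slightly downward, and most likely within the scatter. Compound 4 is estimated to give 12%, with a range from -15% to 35%.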

Compound 4, a percentage reported as inhibition, at one concentration (the size of the read-out at that concentration, not a potency): 31%
For compound 4 the middle estimate is 19 percentage points below the measured one; measured number inside the range.
By their numbers in this assay, from the lowest: compound 2; then compounds 1 and 3 (each within the scatter of the next); then compound 4.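

Among the compounds shown here, putting 1,3-thiazol-2-yl in place of 1H-imidazol-2-yl on a sulfur gives the first step in this set that can be read as a single change: in this assay it produces a number 12 percentage points higher from compound 1 to compound 4 (beyond the scatter) with the rest of the structure untouched. This shows that the ring on this sulfur can be exchanged without losing inhibition at the concentration tested, and that in this pair a hydrogen-bond donor on that ring, present in the 1H-imidazol-2-yl group and absent from the 1,3-thiazol-2-yl group, is not needed to reach this level. Nothing available here explains the rise, so the swap of a ring nitrogen bearing hydrogen for a ring sulfur stands only as an observation.

As far as these compounds go, it remains open whether a 1,3-oxazol-2-yl ring or a six-membered pyridin-2-yl ring on the same sulfur would give a higher or lower number than the 1,3-thiazol-2-yl group does. Also open, from the compounds shown here alone, is whether the same exchange gives a similar step on a different core, such as that of compound 3, and how the pair compares in potency, which a reading at one concentration cannot show.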